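Methoxy for Sulfamoyl, Starting from an Assay Limit

The compounds below may be only part of what the source reports. "The series", "measured", "known", "first", "only" and "open" are said of these compounds alone.

Compound 1, `O=C(Nc1ccc(-c2noc(-c3cccc(NS(=O)(=O)c4ccccc4)c3)n2)c(Cl)c1)c1cccnc1`: > 10000 nM in a functional assay on MDA-MB-231 cells (Homo sapiens) for antiproliferative activity, read by MTT assay, with a stated time of 72 h (on this read-out lower numbers stand for stronger inhibition and higher numbers for weaker inhibition), a limit rather than a number.
Compound 2, `Cc1ccc(S(=O)(=O)Nc2cccc(-c3nc(-c4ccc(NC(=O)c5cccnc5)cc4Cl)no3)c2)cc1`: > 10000 nM in this assay, again a limit.
Compound 3, `NS(=O)(=O)c1ccc(NC(=O)Nc2cccc(-c3nc(-c4ccc(NC(=O)c5cccnc5)cc4Cl)no3)c2)cc1`: > 10000 nM in this assay, again a limit.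

All three measured compounds share a core and sit at the limit of > 10000 nM in this assay, at which 3 of the 3 values shown sit, so no real number is known for any of them. Among the compounds with values here, the one step among them, a step that the two limits leave unreadable from compound 1 to compound 2, cannot be sized for that reason. Compound 3 therefore stands only at the limit, with nothing to place it above or below compound 1 or compound 2.

Compound 4, `COc1ccc(NC(=O)Nc2cccc(-c3nc(-c4ccc(NC(=O)c5cccnc5)cc4Cl)no3)c2)cc1`, differs from compound 3 by methoxy in place of sulfamoyl on an aromatic carbon. Within the data shown here, no measured step bears on this change, and the lone step available is itself unreadable. Since compound 3 gives > 10000 nM, compound 4 is expected to remain in the same region, with a step that the limit leaves unreadable from compound 3 to compound 4, most likely again reported as a limit. The estimate for compound 4 is 15000 nM, between 5000 nM and 50000 nM.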

Compound 4, half-maximal inhibitory concentration: 3000 nM
Compound 4: middle estimate off by 5.0-fold (0.70 log units), on the high side; the whole stated range lies above it.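

Methoxy in place of sulfamoyl on an aromatic carbon, para to a large group, gives an at least 3.3-fold lower number from compound 3 to compound 4 (0.52 log units; beyond the scatter) in this assay, which shows that this one change can bring the series off the limit with the rest of the structure kept. (4-Methoxyphenyl)carbamoyl on the nitrogen gives an at least 3.3-fold lower number from compound 2 to compound 4 (0.52 log units; beyond the scatter) where it replaces (4-methylphenyl)sulfonyl and an at least 3.3-fold lower number from compound 1 to compound 4 (0.52 log units; beyond the scatter) where it replaces phenylsulfonyl, so compound 4 alone among the compounds shown carries a real number. All three steps are minimum sizes, since the other compounds give only a limit: the limit of > 10000 nM in this assay, at which 3 of the 4 values shown sit.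

The compounds shown leave open whether methoxy itself is needed at this place, or whether a hydroxyl, a chlorine or an amine there would give a similar number. They also leave open whether methoxy would have the same effect on the sulfonyl-linked compound 1 or compound 2.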